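Chloromethylbenzyl purines: dropping one chloro from compound 2

The source may report more compounds than this note shows. Statements on the series, on what has been measured and on what is new or still open speak of the compounds shown alone.

Working notes on a small set of chloromethylbenzyl-substituted fused heterocycles tested in a functional assay on SN12C cells (Homo sapiens) for cytotoxicity, read by sulforhodamine B assay, with a stated time of 48 h; on this read-out higher numbers stand for lower toxicity in this test and lower numbers for higher toxicity in this test. Compound 1 `ClCc1ccc(Cn2cnc3c(Cl)ncnc32)cc1` gives 5370 nM in this assay. Compound 3 `ClCc1ccccc1Cn1cnc2c(Cl)nc(Cl)nc21` gives 4670 nM in this assay. These two values sit within the usual scatter of each other, so no order is drawn among them. Compound 2 `ClCc1cccc(Cn2cnc3nc(Cl)nc(Cl)c32)c1` gives only "not determined" (no result reported) in this assay; its result is simply absent, so it stands nowhere on the numbers shown. Compound 4 `ClCc1cccc(Cn2cnc3ncnc(Cl)c32)c1` is the not yet measured analogue, differing from compound 2 by hydrogen in place of chloro on an aromatic carbon. Within the data shown here, no step between measured compounds is available for this change, and with compound 2 lacking a number the step from compound 2 to compound 4 in this assay cannot be sized; the expectation is that it lies within the scatter, with no clear direction. Given that compound 1 shows 5370 nM and compound 3 shows 4670 nM, compound 4 is expected to fall in the same region, estimated at 5000 nM with a range of 2000 nM to 13000 nM.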

Compound 4, concentration lethal to 50% of the cells: 6160 nM
Estimate against measurement, compound 4: 1.2-fold (0.09 log units) below, and the stated range covers the measured number.
By their numbers in this assay, from the lowest: compounds 3, 1 and 4 (each within the scatter of the next).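

Among these compounds, with no number for compound 2, no step from compound 2 to compound 4 can be read. The compounds shown leave open what replacing chloro with hydrogen on that aromatic carbon does to the read-out. No measured evidence bears on this result.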